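Amide to urea: a single swap on the shared core

The compounds below may be only part of what the source reports. "The series", "measured", "known", "first", "only" and "open" are said of these compounds alone.

Compound 1 `COc1cc(-c2nn(-c3cccc(NC(=O)c4ccc(Cl)c(C(F)(F)F)c4)c3)cc2-c2ccncc2)ccc1Cl` gives 267 nM. Compound 2 `O=C(Nc1cccc(-n2cc(-c3ccncc3)c(-c3ccc(Cl)c(O)c3)n2)c1)Nc1cc(C(F)(F)F)cc(C(F)(F)F)c1` gives 647 nM.

In a functional assay on UO-31 cells (Homo sapiens) for inhibition, read by sulforhodamine B assay, with a stated time of 48 h (a higher number here means a weaker inhibitor of growth, a lower number a stronger inhibitor of growth), compound 1 has the lower of the two numbers, so it is the stronger growth inhibitor of the pair; compound 2 sits beyond the usual scatter above it. Compound 2 differs from compound 1 in more than one place, so its number alone cannot be tied to any single change.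

The new compound 3 `COc1cc(-c2nn(-c3cccc(NC(=O)Nc4ccc(Cl)c(Cl)c4)c3)cc2-c2ccncc2)ccc1Cl` keeps the core of compound 1 and changes one thing: (3,4-dichlorophenyl)amino in place of 4-chloro-3-(trifluoromethyl)phenyl on a carbonyl carbon. Going by the values given here, no measured pair shows what this change does on this core. Among the compounds with values here, compound 2, the only other compound carrying a urea, gives the weaker number, but it also carries other differences, so it is only a loose hint.

For compound 3 a small weakening is expected, a 1.6-fold higher number from compound 1 to compound 3 (0.20 log units; within the scatter), close to the scatter. Compound 3 is estimated at 420 nM, with a range of 150 nM to 1200 nM.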

Compound 3, concentration for 50% growth inhibition: 845 nM
Compound 3: middle estimate off by 2.0-fold (0.30 log units), on the low side, and the stated range covers the measured number.
By their numbers in this assay, from the lowest: compound 1; then compounds 2 and 3 (each within the scatter of the next).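

In this assay, going by these compounds alone, putting (3,4-dichlorophenyl)amino in place of 4-chloro-3-(trifluoromethyl)phenyl on a carbonyl carbon gives a 3.2-fold higher number from compound 1 to compound 3 (0.50 log units; beyond the scatter), the first direct reading of a change at this position on the shared core. Growth inhibition is weaker with the urea of compound 3 than with the amide of compound 1, and the step lies beyond the usual scatter. Nothing measured here explains this loss.

As far as these compounds go, the step changes the link and the aryl group together, so the share of each remains open; a urea carrying 4-chloro-3-(trifluoromethyl)phenyl, or an amide carrying 3,4-dichlorophenyl, would separate them. From the compounds shown here alone, how a sulfonamide in place of the amide or urea carbonyl would behave on this core also remains unknown.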